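This account rests on a few compounds, and the source may have more. Where it says the series, first, only, none or still open, it means among the compounds named here.

Measured in an ADME assay on BHK-21 cells (Mesocricetus auratus) for cytotoxicity, read by MTT assay; a higher number here means that more compound is tolerated, a lower number that less compound is tolerated:

compound 1 `C/C(=N\NC(N)=O)c1ccc2c(c1)nc(-c1ccccc1)n2C1CCCCC1`: compound 1 gives > 100000 nM, a limit of the assay.
compound 2 `C/C(=N\NC(N)=O)c1ccc2c(c1)nc(-c1ccc(Cl)cc1)n2C1CCCCC1`: compound 2 gives > 100000 nM, a limit of the assay.
compound 3 `C/C(=N\NC(N)=S)c1ccc2c(c1)nc(-c1ccccc1)n2C1CCCCC1`: compound 3 gives 38000 nM.

From compound 1 to compound 2 the change is chloro in place of hydrogen on an aromatic carbon; the step is a step that the two limits leave unreadable from compound 1 to compound 2, since both values rest on (the limit of > 100000 nM in this assay, at which 2 of the 3 values shown sit). From compound 1 to compound 3 the change is a group of 3 heavy atoms (1 carbon, 1 nitrogen, 1 sulfur; no ring) in place of a group of 3 heavy atoms (1 carbon, 1 nitrogen, 1 oxygen; no ring), on an amine nitrogen, and the step is an at least 2.6-fold lower number from compound 1 to compound 3 (0.42 log units; beyond the scatter). Compound 4 `C/C(=N\NC(N)=S)c1ccc2c(c1)nc(-c1ccc(Cl)cc1)n2C1CCCCC1` is not yet measured in this assay. It differs from compound 3 by chloro in place of hydrogen on an aromatic carbon, the same change as from compound 1 to compound 2, where the limit leaves its size unreadable. Nothing measured shows this chloro shifting the value, so compound 4 is expected to stay close to compound 3, whose value is 38000 nM. For compound 4 the expected step is no change at the digits printed from compound 3 to compound 4 (within the scatter). For compound 4 the estimate is 38000 nM, between 15000 nM and 100000 nM.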

Compound 4, half-maximal cytotoxic concentration: > 100000 nM
Compound 4 gave a limit, no number; the forecaster's own chance of this, stated with the estimate: 30%; at least 2.6-fold (0.42 log units) between middle value and limit.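

In this assay, phenyl to 4-chlorophenyl in the sulfur-bearing compounds gives an at least 2.6-fold higher number from compound 3 to compound 4 (0.42 log units; beyond the scatter). Compound 4 gives > 100000 nM, which is a limit and not a number. The steps from compound 1 to compound 2 and from compound 2 to compound 4 cannot be read, so carrying the chloro change from the oxygen-bearing compounds to the sulfur-bearing ones is neither confirmed nor refuted: the limit of > 100000 nM in this assay, at which 3 of the 4 values shown sit.

Still open, as far as these compounds go, is whether a fluoro, a methoxy or an amine in place of this chloro would give a readable value with sulfur in the side chain. Also open, from the compounds shown here alone, is what a longer chain in place of the cyclohexyl group would do.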